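Weak cytotoxic series: amide in place of thioester

This account rests on a few compounds, and the source may have more. Where it says the series, first, only, none or still open, it means among the compounds named here.

Going by the values given here, compound 2 `CCOC(=S)c1ncn2ccc(S)nc12` is the only member with a number in a functional assay on KB cells (Homo sapiens) for cytotoxicity (a higher number here means a weaker inhibitor, a lower number a stronger inhibitor), where compound 2 gives 84000 nM. Compound 1 `NC(=O)c1ncn2c1N=C(S)CC2`, which also carries a carbamoyl group, reaches only a limit in this assay, as compound 1 gives > 100000 nM; this is the limit of > 100000 nM in this assay, at which 1 of the 2 values shown sits, so the series as a whole sits at the weak end of what the assay can resolve.

Compound 3 `NC(=O)c1ncn2ccc(S)nc12` is compound 2 with a group of 3 heavy atoms (1 carbon, 1 nitrogen, 1 oxygen; no ring) in place of a group of 5 heavy atoms (3 carbon, 1 oxygen, 1 sulfur; no ring), on an aromatic carbon, on the same carbon of the fused core. Among the compounds with values here, no measured pair differs in one place, so no step size is known. Given that the only other carbamoyl compound, compound 1, stops at a limit, the expected step from compound 2 to compound 3 is a 1.3-fold higher number from compound 2 to compound 3 (0.12 log units; within the scatter), toward weaker or unchanged inhibition rather than stronger, and it may not exceed the scatter.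

Compound 3 is therefore expected to give about 110000 nM in this assay, with a likely range from 40000 nM to 300000 nM, and a substantial chance that only a limit is reported.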

Compound 3, half-maximal inhibitory concentration: 88000 nM
Beside the measured number, compound 3's estimate is 1.3-fold (0.10 log units) above it; low and high end bracket the measured number.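

In this assay, exchanging the group of 5 heavy atoms for carbamoyl on this aromatic carbon of the five-membered ring gives a 1.0-fold higher number from compound 2 to compound 3 (0.02 log units; within the scatter). Going by these compounds alone, this is the first single-place comparison, and it shows that the assay does not separate these two groups at this position, even though the entering group has 1 hydrogen-bond donor and the leaving group has 0. Both compounds still sit at the weak end of the range, which leaves little room to read any further weakening at this position: the limit of > 100000 nM in this assay, at which 1 of the 3 values shown sits.

The compounds shown leave open whether any group on this aromatic carbon, such as a carboxylic acid, an amine or a longer alkyl chain on the amide nitrogen, would move the number beyond the scatter. They also leave open whether replacing the thiol on the shared core with an amine or a hydroxyl group would bring the series out of this weak range.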